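This account rests on a few compounds, and the source may have more. Where it says the series, first, only, none or still open, it means among the compounds named here.

Measured in a functional assay for inhibition of sodium/hydrogen exchanger (Oryctolagus cuniculus); on this read-out lower numbers stand for stronger inhibition and higher numbers for weaker inhibition:
Compound 1, `Cc1cc(Cl)c(S(C)(=O)=O)cc1C(=O)N=C(N)N`, gives 25 nM.
Compound 2, `Cc1c(C(=O)N=C(N)N)cc(S(C)(=O)=O)c(Cl)c1C`, gives 58 nM.
Compound 3, `Cc1cc(-n2ccnc2)c(S(C)(=O)=O)cc1C(=O)N=C(N)N`, gives 23 nM.

Compound 2 arises from compound 1 by methyl in place of hydrogen on an aromatic carbon, a change that brought a 2.3-fold higher number from compound 1 to compound 2 (0.37 log units; beyond the scatter). The core of compound 3 differs from that of compound 1 by 1H-imidazol-1-yl in place of chloro on an aromatic carbon, and that gave a 1.1-fold lower number from compound 1 to compound 3 (0.04 log units; within the scatter).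

Compound 4, `Cc1cc(-n2ccnc2C)c(S(C)(=O)=O)cc1C(=O)N=C(N)N`, is not yet measured. It comes from compound 3 by methyl in place of hydrogen on an aromatic carbon. Within the data shown here, this is the same kind of change as the one from compound 1 to compound 2, but the place differs: in compound 2 the methyl sits on a six-membered aromatic ring of carbon only, ortho to a chloro group and ortho to a methyl group, whereas in compound 4 it sits on a five-membered aromatic ring with 2 nitrogen, between two ring nitrogen atoms, next to the ring atom that bears a large group. In this assay, among the measured compounds shown here, the step is expected to be a 2.0-fold higher number from compound 3 to compound 4 (0.29 log units; within the scatter), an expectation resting on the earlier step of a 2.3-fold higher number from compound 1 to compound 2 (0.37 log units; beyond the scatter), since the new place has no measured precedent. Compound 4 is therefore estimated at 45 nM, expected to fall between 20 nM and 110 nM.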

Compound 4, half-maximal inhibitory concentration: 29 nM
Estimate against measurement, compound 4: 1.6-fold (0.19 log units) above; the measured number falls inside the stated range.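

In this assay, methyl in place of hydrogen on the imidazole gave a 1.3-fold higher number from compound 3 to compound 4 (0.10 log units; within the scatter), and 2-methyl-1H-imidazol-1-yl in place of chloro gave a 1.2-fold higher number from compound 1 to compound 4 (0.06 log units; within the scatter). The two methyl steps cannot be told apart in size, so on this evidence the change carries from one core to the other: the same change on two cores in this assay, a 2.3-fold higher number (0.37 log units; beyond the scatter) from compound 1 to compound 2 and a 1.3-fold higher number (0.10 log units; within the scatter) from compound 3 to compound 4, 1.8-fold (0.26 log units) apart, within the scatter of two such steps. This does not establish a rule for the series, as the methyl sits on a different ring in each pair and two steps are a small sample.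

The compounds shown leave open what an ethyl group, an amine or a carboxylic acid in place of this methyl on the imidazole would do to the number.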